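The source may hold more compounds than are shown below. What is called first, only, known or untested is meant among the compounds shown, and "the series" means these compounds.

Among the measured compounds shown here, in an ADME assay on PBMC cells (Homo sapiens) for cytotoxicity (a lower number here means that less compound is tolerated, a higher number that more compound is tolerated), compound 1 `CC(CCNC(=O)c1c(Cl)cncc1Cl)N1CCC(C(Oc2cccc(C(=O)O)n2)c2ccc(C(F)(F)F)cc2)CC1` gives 28700 nM, the lowest of the two numbers known so far. Compound 2 `CC(CCNC(=O)c1c(Cl)cncc1Cl)N1CCC(C(=O)c2ccc(Br)cc2)CC1` gives 189000 nM in this assay, a gap from compound 1 that lies beyond the scatter. Compound 3 `Cc1cccc(OC(c2ccc(C(F)(F)F)cc2)C2CCN(C(C)CCNC(=O)c3c(Cl)cncc3Cl)CC2)n1` has not been measured yet. It differs from compound 1 in one place: methyl in place of carboxy on an aromatic carbon. For the measured compounds named here, no step between measured compounds covers this change, so nothing in the data fixes its size. A small step towards a lower number, if any at all, is expected, and a 1.4-fold lower number from compound 1 to compound 3 (0.16 log units; within the scatter) is the estimated step in this assay. Compound 3 is expected to give about 20000 nM, within a range from 7000 nM to 60000 nM.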

Compound 3, half-maximal cytotoxic concentration: 6700 nM
Estimate against measurement, compound 3: 3.0-fold (0.47 log units) above; measured number outside the range, below it.
By their numbers in this assay, from the lowest: compound 3; then compound 1; then compound 2.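

In this assay, replacing carboxy with methyl on the aromatic carbon next to the ring nitrogen gives a 4.3-fold lower number from compound 1 to compound 3 (0.63 log units; beyond the scatter). Among the compounds shown here, this is the first change confined to one place in this set, and it shows that the group at this position alone can move the number beyond the scatter, towards less compound tolerated. Nothing at hand explains the size of this step. On these data alone, whether an amine or a methoxy group at this position would stay near compound 1 or near compound 3 remains open. Also open, as far as these compounds go, is whether an ethyl group or a longer chain would lower the number further than methyl.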